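This account rests on a few compounds, and the source may have more. Where it says the series, first, only, none or still open, it means among the compounds named here.

Of the compounds shown here, three sharing one core have been measured in an ADME assay on Ava5 cells (Homo sapiens) for cytotoxicity; on this read-out higher numbers stand for lower toxicity in this test and lower numbers for higher toxicity in this test. Compound 1 `NC(=S)Nc1cccc(OCCCCCc2ccccc2)c1` gives 22000 nM in this assay. Compound 2 `NC(=S)Nc1cccc(OCCCCCOc2ccccc2)c1` is reported only as a limit, > 50000 nM, in this assay. Compound 3 `NC(=S)Nc1cccc(OCCCCCOc2ccc(F)cc2)c1` gives 5000 nM in this assay, the lowest of the two numbers on record, and the gap to the nearest number is a 4.4-fold lower number from compound 1 to compound 3 (0.64 log units; beyond the scatter). The steps of an at least 2.2-fold higher number from compound 1 to compound 2 (0.35 log units; beyond the scatter) and an at least 10-fold lower number from compound 2 to compound 3 (1.00 log units; beyond the scatter) show that the phenoxy group and its fluorine each shift the number beyond the scatter. Compound 4 `NC(=S)Nc1cccc(OCCCCCOc2ccc(Br)cc2)c1` carries one change from compound 3: bromo in place of fluoro on an aromatic carbon. Among the measured compounds shown here, no measured step compares two halogens at this place; the only step touching it, an at least 10-fold lower number from compound 2 to compound 3 (1.00 log units; beyond the scatter), swapped a hydrogen for a fluorine. With both compounds carrying a halogen there, compound 4 is expected to stay close to compound 3, with a step of a 1.3-fold lower number from compound 3 to compound 4 (0.10 log units; within the scatter) that is not expected to go beyond the scatter. Compound 4 is therefore estimated at 4000 nM in this assay, with a range from 1500 nM to 12000 nM.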

Compound 4, half-maximal cytotoxic concentration: 19000 nM
For compound 4 the middle estimate is 4.8-fold (0.68 log units) below the measured one; the whole stated range lies below it.
By their numbers in this assay, from the lowest: compound 3; then compounds 4 and 1 (each within the scatter of the next). At a limit, above all of these: compound 2.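

In this assay, exchanging one halogen for another on this aromatic carbon is not a neutral change, since the number moves beyond the scatter (a 3.8-fold higher number from compound 3 to compound 4 (0.58 log units; beyond the scatter)). Bromo in place of hydrogen also gives a lower number, which here means more toxicity in this test (an at least 2.6-fold lower number from compound 2 to compound 4 (0.42 log units; beyond the scatter)), while the 4-bromophenoxy compound cannot be told apart from the phenyl-ended compound (a 1.2-fold lower number from compound 1 to compound 4 (0.06 log units; within the scatter)). Compound 2 is reported only as a limit, so the step from it gives a bound and not an exact size: (the limit of > 50000 nM in this assay, at which 1 of the 4 values shown sits).

As far as these compounds go, with only fluoro and bromo at this place, it remains open how the number would run across the halogens, and a chloro or iodo group would test this. From the compounds shown here alone, it also remains open whether a methoxy group or an amine at this place, or a longer chain, would lower the number as these two halogens do.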